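Aryl group variation on the carbonyl carbon

The source may hold more compounds than are shown below. What is called first, only, known or untested is meant among the compounds shown, and "the series" means these compounds.

Working notes on a short series sharing one core with a variable aryl ketone. Compound 1 `C=C(C)Cn1cc(/C=C/C(=O)CC(=O)C(=O)OCC)c2ccccc21` carries a different substitution pattern and an ester; in an assay on isolated protein for inhibition of DNA nucleotidylexotransferase (Homo sapiens), read by scintillation counting, with a stated time of 10 min (a higher number here means a weaker inhibitor, a lower number a stronger inhibitor), compound 1 gives only a limit, > 40 uM, and no number. Compound 2 `O=C(/C=C/c1cc(C(=O)c2ccccc2F)c[nH]1)CC(=O)C(=O)O` gives 1.7 uM in this assay. Compound 3 `O=C(/C=C/c1cc(C(=O)c2cccc(F)c2)c[nH]1)CC(=O)C(=O)O` gives 0.78 uM in this assay, the lowest of the two numbers shown; the step of a 2.2-fold lower number from compound 2 to compound 3 (0.34 log units; beyond the scatter) is the only measured change on the aryl ring, and it is modest. The only other entry is the limit of > 40 uM in this assay, at which 1 of the 3 values shown sits, which bears on compound 1 alone.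

The next compound, compound 4 `N#Cc1ccc(C(=O)c2c[nH]c(/C=C/C(=O)CC(=O)C(=O)O)c2)cc1`, differs from compound 3 by 4-cyanophenyl in place of 3-fluorophenyl on a carbonyl carbon. The one measured step that touches this position, a 2.2-fold lower number from compound 2 to compound 3 (0.34 log units; beyond the scatter), moved the fluorine within the same ring and was small; a change to a different substituent and a different ring position is not covered by any shown pair, so the direction is open. A step of about the size of the fluorine shift, or none beyond the scatter, is expected: a 1.3-fold higher number from compound 3 to compound 4 (0.11 log units; within the scatter). Compound 4 is therefore estimated at 1 uM in this assay, within a range from 0.35 uM to 3 uM.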

Compound 4, concentration for 50% inhibition: 1.1 uM
Estimate against measurement, compound 4: 1.1-fold (0.04 log units) below; the range from low to high includes it.
By their numbers in this assay, from the lowest: compounds 3, 4 and 2 (each within the scatter of the next, the first and the last beyond it). At a limit, above all of these: compound 1.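

In this assay the 4-cyanophenyl group on the carbonyl carbon does not separate from either fluorinated aryl group: replacing 3-fluorophenyl gives a 1.4-fold higher number from compound 3 to compound 4 (0.15 log units; within the scatter) and replacing 2-fluorophenyl gives a 1.5-fold lower number from compound 2 to compound 4 (0.19 log units; within the scatter) and both steps stay inside the usual scatter. Among the compounds shown here, the position therefore accepts a nitrile-bearing ring, with its extra heavy atom and its hydrogen-bond acceptor, with no readable change in either direction, and the only difference on this aryl ring that still exceeds the scatter is the one between compound 2 and compound 3. Nothing measured here accounts for this outcome, since the one available observation concerns only the limit of compound 1 and has no bearing on the aryl group.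

The step to compound 4 changes the substituent and its place on the ring together, so 3-cyanophenyl and 4-fluorophenyl would be needed to tell those two changes apart. The compounds shown also leave open how this position responds to an amine on the aryl ring, or to a saturated cyclohexyl group in place of the aryl ring.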